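A Methyl Oxadiazole Replaces Thiophene

This account rests on a few compounds, and the source may have more. Where it says the series, first, only, none or still open, it means among the compounds named here.

compound 1 `C[Si](C)(C)Cn1nnc2c(C(N)=O)ncn2c1=O` gives 45600 nM
compound 2 `C[Si](C)(C)CCOCn1nnc2c(C(N)=O)ncn2c1=O` gives 25300 nM
compound 3 `NC(=O)c1ncn2c(=O)n(Cc3cccs3)nnc12` gives > 50000 nM (a limit)
compound 4 `Cc1noc(Cn2nnc3c(C(N)=O)ncn3c2=O)n1` is not yet measured

These values come from a functional assay on U-373MG ATCC cells for inhibition, with U373 MG (Homo sapiens) as the target, read by MTT assay, with a stated time of 7 days; a lower number here means a stronger inhibitor of growth, a higher number a weaker inhibitor of growth. Compound 3 stands at > 50000 nM, which is a limit of the assay and not a number.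

Compound 4 differs from compound 3 in one group: 3-methyl-1,2,4-oxadiazol-5-yl in place of thiophen-2-yl on a saturated chain carbon bound to an aromatic nitrogen. It carries 3-methyl-1,2,4-oxadiazol-5-yl in place of thiophen-2-yl on a saturated chain carbon bound to an aromatic nitrogen.

Among the compounds with values here, three measured steps bear on this, since each exchanges a group at that same place. They are a 1.8-fold lower number from compound 1 to compound 2 (0.26 log units; within the scatter) and an at least 1.0-fold higher number from compound 1 to compound 3 (0.04 log units; that floor lies within the scatter) and an at least 1.9-fold higher number from compound 2 to compound 3 (0.29 log units; that floor lies within the scatter). All three lie within the scatter, the last two only as floors. Exchanges here have so far shown no step beyond the scatter, and none is expected in this assay this time. The expected step is an at least 1.1-fold lower number from compound 3 to compound 4 (0.04 log units; that floor lies within the scatter). Another limit is about as likely as a number. Compound 4 is estimated at 45000 nM, with an expected range from 22000 nM to 90000 nM.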

Compound 4, concentration for 50% growth inhibition: > 50000 nM
Compound 4 ended at the assay's limit; the forecaster's own chance of this, stated with the estimate: 55%; middle value at least 1.1-fold (0.04 log units) from the limit.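

In this assay, compound 4 gives a limit and not a number, as compound 3 does, so the step between them cannot be read, and the change from thiophen-2-yl to 3-methyl-1,2,4-oxadiazol-5-yl has no readable size: the limit of > 50000 nM in this assay, at which 2 of the 4 values shown sit.

Set against the two chains without a ring, the readable floors are an at least 1.9-fold higher number from compound 2 to compound 4 (0.29 log units; that floor lies within the scatter) and an at least 1.0-fold higher number from compound 1 to compound 4 (0.04 log units; that floor lies within the scatter), so no exchange at this place has yet shown a step beyond the scatter. Both five-membered aromatic rings shown on the saturated chain carbon bound to an aromatic nitrogen, with 1 hetero atom or with 3, now end at a limit, while compound 1 and compound 2, which carry no ring there, give numbers.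

Going by these compounds, whether compound 3 and compound 4 truly differ stays open. So does whether a phenyl ring or a carboxylic acid at this place would give a number beyond the scatter from compound 1 or compound 2.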